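The compounds below may be only part of what the source reports. "The series", "measured", "known", "first", "only" and "open" are said of these compounds alone.

Measured compounds in a functional assay on U-937 cells (Homo sapiens) for cytotoxicity, read by MTT assay, with a stated time of 24 h; on this read-out higher numbers stand for weaker inhibition and lower numbers for stronger inhibition:
- compound 1 `BrCCCCOc1c(Br)cc(Br)cc1Oc1ccc(Br)cc1Br`: 29 ug/mL
- compound 2 `BrCCOc1c(Br)cc(Br)cc1Oc1ccc(Br)cc1Br`: 32.5 ug/mL

Compound 1 gives the lowest of the two numbers; compound 2 is its nearest, and a 1.1-fold higher number from compound 1 to compound 2 (0.05 log units; within the scatter), so the two are not told apart. The new compound 3 `OCCOc1c(Br)cc(Br)cc1Oc1ccc(Br)cc1Br` arises from compound 1 by hydroxy in place of 2-bromoethyl on a saturated chain carbon, two bonds along the chain from an oxygen on an aromatic ring. For the measured compounds named here, of the measured steps only that from compound 1 to compound 2 bears on it, and only in part: it shortens the chain at the same place, reading bromo in place of 2-bromoethyl, and it stayed within the scatter. Going by the values given here, nothing measured here shows a hydroxy at that position, so the effect of the entering hydroxy rests on no step at all. The expectation is therefore no step beyond the scatter, and the estimated step is a 1.2-fold higher number from compound 1 to compound 3 (0.09 log units; within the scatter). On these data alone, compound 3 is estimated to give 36 ug/mL in this assay, with a range from 17 ug/mL to 75 ug/mL; the range is kept wide since the hydroxy is untested here.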

Compound 3, half-maximal inhibitory concentration: 34.5 ug/mL
Compound 3: middle estimate off by 1.0-fold (0.02 log units), on the high side, within the range that was stated.
By their numbers in this assay, from the lowest: compounds 1, 2 and 3 (each within the scatter of the next).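

In this assay, a hydroxy on a saturated chain carbon, two bonds along the chain from an oxygen on an aromatic ring, can now be read against both bromo compounds: hydroxy in place of 2-bromoethyl gives a 1.2-fold higher number from compound 1 to compound 3 (0.08 log units; within the scatter), and hydroxy in place of bromo gives a 1.1-fold higher number from compound 2 to compound 3 (0.03 log units; within the scatter). The earlier pair varied only the chain length with bromo kept on the chain, whereas these steps show that bromo itself can give way to hydroxy, which brings in 1 hydrogen-bond donor and 1 hydrogen-bond acceptor, with the number staying within the scatter. No measurement at hand accounts for this flat result.

On these data alone, whether an amine or a carboxylic acid on the chain, or a longer chain carrying hydroxy, would move the number beyond the scatter remains open. Also open, as far as these compounds go, is whether changes on the shared core, rather than on the chain, would do so.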